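Moving to 5,6-dimethylpyridin-2-yl on the shared core

The source may report more compounds than this note shows. Statements on the series, on what has been measured and on what is new or still open speak of the compounds shown alone.

In an ADME assay for permeability, using PAMPA, with a stated time of 4 h (a higher number here means that the compound crosses the layer faster, a lower number that the compound crosses the layer more slowly), compound 1 `Cn1c(COc2cccc(C(=O)O)c2)nc2ccc(Oc3ncccc3Cl)cc21` gives 8.1 10^-6 cm/s, compound 2 `Cc1cccc(Oc2ccc3nc(COc4cccc(C(=O)O)c4)n(C)c3c2)n1` gives 2.7 10^-6 cm/s and compound 3 `Cc1cccnc1Oc1ccc2nc(COc3cccc(C(=O)O)c3)n(C)c2c1` gives 6 10^-6 cm/s. The standing of compound 3 rests on two steps: a 1.4-fold lower number from compound 1 to compound 3 (0.13 log units; within the scatter), and a 2.2-fold higher number from compound 2 to compound 3 (0.35 log units; beyond the scatter). Compound 4 `Cc1ccc(Oc2ccc3nc(COc4cccc(C(=O)O)c4)n(C)c3c2)nc1C` differs from compound 3 by 5,6-dimethylpyridin-2-yl in place of 3-methylpyridin-2-yl on an oxygen on an aromatic ring. The entering 5,6-dimethylpyridin-2-yl resembles the group of compound 2 more closely than the group it replaces, so the reading of compound 2, 2.7 10^-6 cm/s, is the best guide, along with a 3.0-fold lower number from compound 1 to compound 2 (0.48 log units; beyond the scatter). Among the measured compounds shown here, no measured step isolates the added methyl. A modest fall is therefore expected, namely a 2.0-fold lower number from compound 3 to compound 4 (0.30 log units; within the scatter). Compound 4 is estimated at 3 10^-6 cm/s, with an expected range of 1.5 10^-6 cm/s to 6 10^-6 cm/s.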

Compound 4, apparent permeability: 7.7 10^-6 cm/s
The estimate for compound 4 lay 2.6-fold (0.41 log units) below the measured number, outside the stated range (above it).
By their numbers in this assay, from the lowest: compound 2; then compounds 3, 4 and 1 (each within the scatter of the next).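

In this assay, among the compounds shown here, one further methyl gives a 2.9-fold higher number from compound 2 to compound 4 (0.46 log units; beyond the scatter), the first step to isolate this added methyl. The entering 5,6-dimethylpyridin-2-yl gives a 1.3-fold higher number from compound 3 to compound 4 (0.11 log units; within the scatter) against 3-methylpyridin-2-yl and a 1.1-fold lower number from compound 1 to compound 4 (0.02 log units; within the scatter) against 3-chloropyridin-2-yl, so these three groups on the oxygen cannot be told apart, and only the 6-methylpyridin-2-yl of compound 2 stands apart. No evidence at hand explains the effect of the added methyl. Still open, as far as these compounds go, is how an amine or a methoxy group on this ring would read in this assay.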